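From ethyl to carbamoylmethyl: notes on compound 4

A few compounds are considered here, and "the series" means these few. Any claim that something is new, unique, unknown or untested is made for them only; others in the source may bear on it.

In a functional assay on HCT-116 cells (Homo sapiens) for antiproliferative activity, read by MTT assay, with a stated time of 48 h (on this read-out higher numbers stand for weaker inhibition and lower numbers for stronger inhibition), compound 1 `CCOc1ccc(-c2cc3c(cn2)[nH]c(=O)n3-c2cc(OC)c(OC)c(OC)c2)cc1F` gives 7220 nM and compound 2 `COc1ccc(-c2cc3c(cn2)n(C)c(=O)n3-c2cc(OC)c(OC)c(OC)c2)cc1O` gives 1060 nM. Compound 3 `CCn1c(=O)n(-c2cc(OC)c(OC)c(OC)c2)c2cc(-c3ccc(OC)c(O)c3)ncc21` stands at > 20000 nM, which is a limit of the assay and not a number. Compound 4 `COc1ccc(-c2cc3c(cn2)n(CC(N)=O)c(=O)n3-c2cc(OC)c(OC)c(OC)c2)cc1O` carries carbamoyl in place of methyl on a saturated chain carbon bound to an aromatic nitrogen. For the measured compounds named here, one measured step bears on this place: an at least 18-fold higher number from compound 2 to compound 3 (1.27 log units; beyond the scatter), with methyl in place of hydrogen. That step is large, but it does not cover a carbamoyl group. A partial move toward stronger inhibition in this assay is therefore expected, not a full return to the level of compound 2. The expected change is an at least 2.5-fold lower number from compound 3 to compound 4 (0.39 log units; beyond the scatter). For compound 4 the estimated value is 8000 nM, with an expected range of 2500 nM to 20000 nM.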

Compound 4, half-maximal inhibitory concentration: 8890 nM
Compound 4: middle estimate off by 1.1-fold (0.05 log units), on the low side; the measured number falls inside the stated range.
By their numbers in this assay, from the lowest: compound 2; then compounds 1 and 4 (each within the scatter of the next). At a limit, above all of these: compound 3.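

In this assay the loss seen with ethyl on this saturated chain carbon does not hold for every larger group, since carbamoylmethyl gives an at least 2.2-fold lower number from compound 3 to compound 4 (0.35 log units; beyond the scatter). Compound 3 is known only as a limit of the assay: the limit of > 20000 nM in this assay, at which 1 of the 4 values shown sits. The recovery remains partial, with an 8.4-fold higher number from compound 2 to compound 4 (0.92 log units; beyond the scatter) and the methyl of compound 2 still ahead of carbamoylmethyl.

As far as these compounds go, whether a carboxylic acid, an amine or a longer chain at this place would come closer to compound 2 stays open. Also open, from the compounds shown here alone, is whether the recovery is specific to the carbamoyl group.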